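Aryl swap on the carbonyl: methoxyphenyl replaces dichlorophenyl

The compounds below may be only part of what the source reports. "The series", "measured", "known", "first", "only" and "open" are said of these compounds alone.

Compound 1 `COc1cc(-c2cc(/C=C/C(=O)c3ccc(N)cc3)[nH]n2)cc(OC)c1OC` and compound 2 `COc1cc(-c2cc(/C=C/C(=O)c3ccc(Cl)c(Cl)c3)[nH]n2)cc(OC)c1OC` share one core and differ only in the aryl group on the carbonyl carbon. In a functional assay on OVCAR-8 cells (Homo sapiens) for cytotoxicity, read by sulforhodamine B assay, with a stated time of 48 h, tested at 1 uM (a higher number here means a weaker effect of the compound at the concentration tested, a lower number a stronger effect), compound 1 gives 81%, and compound 2 gives 88%. Among the measured compounds shown here, the step of a number 7 percentage points higher from compound 1 to compound 2 (within the scatter) is the only measured step so far. For the measured compounds named here, compound 2 therefore holds the highest of the two numbers known, with compound 1 nearest to it, and the gap between the two lies within the scatter.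

Going by the values given here, compound 3 `COc1ccc(C(=O)/C=C/c2cc(-c3cc(OC)c(OC)c(OC)c3)n[nH]2)cc1` is the next member to be tested. 4-methoxyphenyl in place of 3,4-dichlorophenyl on a carbonyl carbon The one measured comparison that bears on this change is the earlier exchange of one aryl group for another on the same carbonyl carbon, a number 7 percentage points higher from compound 1 to compound 2 (within the scatter), which stayed within the scatter. Among the compounds with values here, nothing among the measured compounds separates a 4-methoxyphenyl from the groups already tried at that position. The expected step in this assay is a number 3 percentage points lower from compound 2 to compound 3 (within the scatter), that is, no change beyond the scatter. Compound 3 is estimated at 85%, with a range from 70% to 98%.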

Compound 3, a percentage reported as activity, at one concentration (the size of the read-out at that concentration, not a potency): 86%
For compound 3 the middle estimate is 1 percentage points below the measured one, within the range that was stated.
By their numbers in this assay, from the lowest: compounds 1, 3 and 2 (each within the scatter of the next).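

In this assay, the exchange of 3,4-dichlorophenyl for 4-methoxyphenyl on the carbonyl carbon gives a number 2 percentage points lower from compound 2 to compound 3 (within the scatter), and methoxy in place of amino on an aromatic carbon gives a number 5 percentage points higher from compound 1 to compound 3 (within the scatter). The series now holds three aryl groups at this carbonyl carbon, and every pair among compounds 1, 2 and 3 lies within the scatter, so the earlier single comparison is no longer an isolated case. The exchange that yields compound 3 also replaces two chlorines with an oxygen and raises the hydrogen-bond acceptor count of the group from 0 to 1, yet this brings no change beyond the scatter; no measurement at hand accounts for this flat result.

On these data alone, all three compounds were read at one concentration, so any differences in potency that this single read-out does not capture remain open, as does whether any group at this carbonyl carbon can move the number beyond the scatter. A carboxylic acid or a longer alkoxy chain in place of the methoxy of compound 3 would extend the comparison, and the shared core outside this aryl group remains unexplored in the compounds shown.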